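Swapping the Aryl Group on a Dihydropyrimidine Core

A few compounds are considered here, and "the series" means these few. Any claim that something is new, unique, unknown or untested is made for them only; others in the source may bear on it.

Compound 1 `CC1=C(C(=O)Nc2ccc([N+](=O)[O-])cc2)C(c2ccc(Br)cc2)N=C(SCc2ccccc2)N1` was tested in a functional assay on the whole organism (artery, strain albino) with Rattus norvegicus as the target, with a stated time of 180 min, at a dose of 10 mg/kg by the oral route (a lower number here means less inhibition, a higher number more inhibition at the dose given (going by the name of the read-out)), where compound 1 gives 19.6%. Among the compounds with values here, its only measured neighbour, compound 2 `CC1=C(C(=O)Nc2ccc([N+](=O)[O-])cc2)C(c2ccc(Br)cc2)N=C(SCc2ccc(F)cc2)N1`, gives 17.5% in this assay, and the step of a number 2.1 percentage points lower from compound 1 to compound 2 (within the scatter) means the two numbers cannot be told apart. The unmeasured compound 3 `CC1=C(C(=O)Nc2ccc([N+](=O)[O-])cc2)C(c2cccc([N+](=O)[O-])c2)N=C(SCc2ccccc2)N1` differs from compound 1 at another place on the shared core: 3-nitrophenyl in place of 4-bromophenyl on a saturated ring carbon. Within the data shown here, no measured step touches that position, since the only known step, a number 2.1 percentage points lower from compound 1 to compound 2 (within the scatter), concerns the benzylsulfanyl group and was within the scatter. With nothing pointing either way, compound 3 is expected to sit near compound 1, so the estimated step is a number 1.6 percentage points lower from compound 1 to compound 3 (within the scatter), no larger than the scatter. The expected read-out for compound 3 in this assay is 18%, with a range from 5% to 35%.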

Compound 3, a percentage reported as inhibition, in the whole organism at one dose (the size of the read-out at that dose, not a potency): 16.5%
Compound 3: the middle estimate sits 1.5 percentage points above what was measured; measured number inside the range.
By their numbers in this assay, from the lowest: compounds 3, 2 and 1 (each within the scatter of the next).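

Within the data shown here, the first measured step at this position, a saturated ring carbon of the shared core, is a number 3.1 percentage points lower from compound 1 to compound 3 (within the scatter) in this assay, so at this dose the two compounds cannot be told apart. The entering 3-nitrophenyl has more heavy atoms than 4-bromophenyl and carries hydrogen-bond acceptors where the leaving group has none, yet this swap gives no gap larger than the scatter. No separate measurement bears on this result, so it remains without an explanation.

On these data alone, this one step changes both the substituent and its number on the aromatic ring, so 3-bromophenyl and 4-nitrophenyl remain open as the comparisons that would separate the two changes. Also open, as far as these compounds go, is how the read-out would respond to a plain phenyl, or to an aromatic ring bearing an amine or a carboxylic acid.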